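Toward a primary sulfonamide on the chain

The source may report more compounds than this note shows. Statements on the series, on what has been measured and on what is new or still open speak of the compounds shown alone.

Measured so far:
Compound 1, `[O-][S+]1CC(Nc2nonc2/C(=N/O)Nc2ccc(F)c(Br)c2)C1`, gives 79 nM.
Compound 2, `O=S(=O)(CCNc1nonc1/C(=N/O)Nc1ccc(F)c(Br)c1)NCC1CC1`, gives 268 nM.

Both numbers come from an assay on HeLa cells for inhibition of Indoleamine 2,3-dioxygenase 1 (Homo sapiens), read by spectrophotometry, with a stated time of 24 h; on this read-out lower numbers stand for an effect already at smaller amounts and higher numbers for an effect only at larger amounts of compound. Of the two, compound 2 stands with the highest number; its nearest neighbour, compound 1, lies at a lower number, and the gap between them is beyond the usual scatter of this assay.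

The step from compound 2 to compound 3, `NS(=O)(=O)CCCNc1nonc1/C(=N/O)Nc1ccc(F)c(Br)c1`, is sulfamoylmethyl in place of (cyclopropylmethyl)sulfamoyl on a saturated chain carbon, two bonds along the chain from a nitrogen on an aromatic ring. Among the compounds with values here, no measured pair shows this change, so its effect is unknown. The shared core and the aryl portion stay untouched; only the terminal sulfonamide portion of the chain is altered.

On the basis of compound 2 alone, the step of a 1.8-fold lower number from compound 2 to compound 3 (0.25 log units; within the scatter) is expected to be small, at most a modest move to a lower number and possibly none beyond the scatter. Compound 3 is therefore estimated at 150 nM, with a range from 50 nM to 450 nM.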

Compound 3, half-maximal effective concentration: 15 nM
Compound 3: middle estimate off by 10-fold (1.00 log units), on the high side; the whole stated range lies above it.
By their numbers in this assay, from the lowest: compound 3; then compound 1; then compound 2.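

In this assay, within the data shown here, putting sulfamoylmethyl in place of (cyclopropylmethyl)sulfamoyl on a saturated chain carbon gives an 18-fold lower number from compound 2 to compound 3 (1.25 log units; beyond the scatter), which shows that this position responds strongly to a change at the chain end, something the earlier compounds could not show. Exchanging the ring-bearing group of compound 1 on the nitrogen for the open chain gives a 5.3-fold lower number from compound 1 to compound 3 (0.72 log units; beyond the scatter), so compound 3 now has the lowest number of the three, with both of its steps beyond the scatter. No accompanying measurement speaks to what lies behind these steps.

The change removes the cyclopropylmethyl group and also alters the chain, so the compounds shown do not separate these two parts of the step. From the compounds shown here alone, whether a carboxylic acid, an amide or a still longer chain would serve at the chain end remains open.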